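This account rests on a few compounds, and the source may have more. Where it says the series, first, only, none or still open, it means among the compounds named here.

Measured compounds:
compound 1 `Nc1cccc(/C=C2\SC(=O)N(Cc3ccc(F)cc3)C2=O)c1`, 142000 nM;
compound 2 `Nc1cccc(/C=C2\SC(=O)N(Cc3ccccc3)C2=O)c1`, 233000 nM;
compound 3 `Nc1cccc(/C=C2\SC(=O)N(Cc3ccc(C(F)(F)F)cc3)C2=O)c1`, > 250000 nM.

In a functional assay on L1210 cells (Mus musculus) for cytotoxicity, read by cell counting, with a stated time of 2 days (a higher number here means a weaker inhibitor, a lower number a stronger inhibitor), compound 2 has the highest of the two numbers shown. Its nearest neighbour is compound 1, and the step of a 1.6-fold higher number from compound 1 to compound 2 (0.22 log units; within the scatter) lies within the scatter. For compound 3 the value > 250000 nM is a limit of the assay, not a number (the limit of > 250000 nM in this assay, at which 1 of the 3 values shown sits). The steps of an at least 1.7-fold higher number from compound 1 to compound 3 (0.24 log units; that floor lies within the scatter) and an at least 1.0-fold higher number from compound 2 to compound 3 (0.03 log units; that floor lies within the scatter) therefore give only floors, and both floors lie within the scatter.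

Compound 4 `Nc1ccc(/C=C2\SC(=O)N(Cc3ccccc3)C2=O)cc1` has not yet been measured. It differs from compound 2 by 4-aminophenyl in place of 3-aminophenyl on a double-bonded chain carbon bound to a double-bonded ring carbon. For the measured compounds named here, none of the measured steps touches this part of the shared core; all three change the substituent on the benzyl ring, and none of them moved the number beyond the scatter. Going by the values given here, no measured step thus bears directly on the change from compound 2 to compound 4, and the data give no ground for expecting a shift beyond the scatter in either direction. Compound 4 is therefore expected to land near compound 2, at an estimated 230000 nM, with a range from 80000 nM to 600000 nM, which amounts to an expected step of a 1.0-fold lower number from compound 2 to compound 4 (0.01 log units; within the scatter).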

Compound 4, half-maximal inhibitory concentration: 38000 nM
Estimate against measurement, compound 4: 6.1-fold (0.78 log units) above; the measured number lies below the stated range.
By their numbers in this assay, from the lowest: compound 4; then compounds 1 and 2 (each within the scatter of the next). At a limit, above all of these: compound 3.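

In this assay, exchanging 3-aminophenyl for 4-aminophenyl on a double-bonded chain carbon bound to a double-bonded ring carbon gives a 6.1-fold lower number from compound 2 to compound 4 (0.79 log units; beyond the scatter), the only step among the compounds shown that is printed as beyond the scatter. For the compounds shown here, the earlier changes, all on the benzyl ring, stayed within the scatter or, where compound 3 was involved, gave only floors, so this position is the first place where a single change clearly moves the number. The leaving and entering groups have the same heavy atoms and the same counts of hydrogen-bond donors and acceptors, so the step reflects how those atoms are joined rather than what they are, though nothing measured here gives a cause for it.

As far as these compounds go, whether the lower number of compound 4 carries over when its benzyl ring bears the fluoro of compound 1 or the trifluoromethyl of compound 3 remains open. So does what a hydroxyl or a dimethylamino group would give in place of the amine of 4-aminophenyl.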